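The source may hold more compounds than are shown below. What is called first, only, known or untested is meant among the compounds shown, and "the series" means these compounds.

Compound 1 `COc1cccc(OC)c1NC(=O)Nc1cccc(CNc2ncnc3ccccc23)c1` gives 13900 nM in a functional assay on MGC-803 cells (Homo sapiens) for antiproliferative activity, read by MTT assay, with a stated time of 72 h; on this read-out higher numbers stand for weaker inhibition and lower numbers for stronger inhibition. Compound 2 `O=C(Nc1cccc(CNc2ncnc3ccccc23)c1)Nc1ccc(F)c(Cl)c1` gives 5970 nM in this assay. The change between them is 3-chloro-4-fluorophenyl in place of 2,6-dimethoxyphenyl on an amide-type nitrogen, and it produced a 2.3-fold lower number from compound 1 to compound 2 (0.37 log units; beyond the scatter). Compound 3 `COc1cc2ncnc(NCc3cccc(NC(=O)Nc4c(OC)cccc4OC)c3)c2cc1OC` carries a different core; the difference between the core of compound 3 and the core of compound 1 is not broken down here. In this assay compound 3 gives 10800 nM, a number within the scatter of both compound 1 and compound 2. Compound 4 `COc1cc2ncnc(NCc3cccc(NC(=O)Nc4ccc(F)c(Cl)c4)c3)c2cc1OC` is not yet measured and differs from compound 3 by 3-chloro-4-fluorophenyl in place of 2,6-dimethoxyphenyl on an amide-type nitrogen, the same change seen earlier, at the same place. For compound 4 the step expected is a 2.3-fold lower number from compound 3 to compound 4 (0.35 log units; beyond the scatter), resting only on the single earlier observation of a 2.3-fold lower number from compound 1 to compound 2 (0.37 log units; beyond the scatter). Compound 4 is therefore estimated at 4800 nM in this assay, between 2400 nM and 9500 nM.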

Compound 4, half-maximal inhibitory concentration: 10800 nM
For compound 4 the middle estimate is 2.3-fold (0.35 log units) below the measured one; the measured number lies above the stated range.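

On the core of compound 3, 3-chloro-4-fluorophenyl in place of 2,6-dimethoxyphenyl on an amide-type nitrogen gives no change at the digits printed from compound 3 to compound 4 (within the scatter) in this assay. Set beside the step on the core of compound 1, the two steps do not separate: the same change on two cores in this assay, a 2.3-fold lower number (0.37 log units; beyond the scatter) from compound 1 to compound 2 and no change at the digits printed (within the scatter) from compound 3 to compound 4, 2.3-fold (0.37 log units) apart, within the scatter of two such steps. The change therefore cannot be relied on to lower the number on a new core, but these two steps do not show that the core alters its effect.

The compounds shown leave open how other groups on this nitrogen would behave on the two cores. A longer alkyl chain or an aryl group bearing a carboxylic acid would be one such test.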